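Methoxy for hydroxy on a bis-enone scaffold: second pairing

The compounds below may be only part of what the source reports. "The series", "measured", "known", "first", "only" and "open" are said of these compounds alone.

Compound 1 `COc1cc(C=C(C(=O)/C=C/c2cccc(OC)c2OC)C(=O)/C=C/c2cccc(OC)c2OC)ccc1O` carries a 4-hydroxy-3-methoxyphenyl group; in a functional assay on SW480 cells (Homo sapiens) for antiproliferative activity, read by sulforhodamine B assay, with a stated time of 48 h (on this read-out higher numbers stand for weaker inhibition and lower numbers for stronger inhibition), compound 1 gives 430 nM. Compound 2 `COc1ccc(C=C(C(=O)/C=C/c2cccc(OC)c2OC)C(=O)/C=C/c2cccc(OC)c2OC)cc1OC` differs by methyl in place of hydrogen on an oxygen on an aromatic ring, and in this assay compound 2 gives 410 nM; the step is a 1.0-fold lower number from compound 1 to compound 2 (0.02 log units; within the scatter). Compound 3 `COc1ccc(OC)c(/C=C/C(=O)C(=Cc2ccc(O)c(OC)c2)C(=O)/C=C/c2cc(OC)ccc2OC)c1` is built on a different core from compound 1; the difference between the two cores is not broken down here. In this assay compound 3 gives 410 nM, level with compound 2 at the digits read and within the scatter of compound 1.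

Compound 4 `COc1ccc(OC)c(/C=C/C(=O)C(=Cc2ccc(OC)c(OC)c2)C(=O)/C=C/c2cc(OC)ccc2OC)c1` is yet to be measured. It differs from compound 3 by methyl in place of hydrogen on an oxygen on an aromatic ring, the same change as that from compound 1 to compound 2, at a place described in the same words. Because that earlier step, a 1.0-fold lower number from compound 1 to compound 2 (0.02 log units; within the scatter), stayed within the scatter, the step from compound 3 to compound 4 is expected to be a 1.0-fold lower number from compound 3 to compound 4 (0.01 log units; within the scatter), essentially flat. Compound 4 is therefore estimated at 400 nM in this assay, with a likely span from 200 nM to 800 nM.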

Compound 4, half-maximal inhibitory concentration: 560 nM
Beside the measured number, compound 4's estimate is 1.4-fold (0.15 log units) below it, within the range that was stated.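

Replacing hydroxy with methoxy on the 4-hydroxy-3-methoxyphenyl group gives a 1.4-fold higher number from compound 3 to compound 4 (0.14 log units; within the scatter) in this assay, so this second pairing, like the first, shows no step beyond the scatter. The two pairings agree across the two cores: the same change on two cores in this assay, a 1.0-fold lower number (0.02 log units; within the scatter) from compound 1 to compound 2 and a 1.4-fold higher number (0.14 log units; within the scatter) from compound 3 to compound 4, 1.4-fold (0.16 log units) apart, within the scatter of two such steps. This shows that, for these two cores and on this read-out, the change carries over with no measurable difference, but it rests on just two pairs, cannot resolve a core dependence smaller than the scatter, and says nothing about any other core or any other read-out.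

Open, from the compounds shown here alone, is whether a longer chain on that oxygen, such as ethoxy or benzyloxy, would stay as flat as methoxy does on both cores. Also open, going by these compounds, is what an amine or a carboxylic acid in place of the hydroxy would do, and whether any such replacement would then carry from one core to the other.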